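Extending the side chain of compound 3

The source may hold more compounds than are shown below. What is called first, only, known or untested is meant among the compounds shown, and "the series" means these compounds.

- Compound 1 `CCc1c(C(F)c2cc(C)cc(C)c2)[nH]c(=O)n(COCc2ccc(I)cc2)c1=O`: > 100000 nM (a limit)
- Compound 2 `Cc1c(C(C)c2c(F)cccc2F)nc(N(C)C)[nH]c1=O`: >= 100000 nM (a limit)
- Compound 3 `CCOCn1c(C(F)c2cc(C)cc(C)c2)c(CC)c(=O)[nH]c1=O`: 85000 nM

Among the compounds with values here, in an ADME assay on MT4 cells (Homo sapiens) for cytotoxicity, read by MTT assay, with a stated time of 96 h (a higher number here means that more compound is tolerated, a lower number that less compound is tolerated), compound 3 gives 85000 nM, the only actual number in the set. Compound 1 and compound 2 each report only a limit.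

Compound 4 `CCc1c(C(F)c2cc(C)cc(C)c2)n(COCc2ccc(C#CCO)cc2)c(=O)[nH]c1=O` follows from compound 3 by one change: 4-(3-hydroxyprop-1-yn-1-yl)phenyl in place of methyl on a saturated chain carbon bound to an oxygen on a saturated carbon. Here 4-(3-hydroxyprop-1-yn-1-yl)phenyl takes the place of methyl on a saturated chain carbon bound to an oxygen on a saturated carbon.

Within the data shown here, no measured step covers this change, so the expectation rests on compound 3 at 85000 nM alone. A modest move towards less compound tolerated is expected, estimated as a 2.1-fold lower number from compound 3 to compound 4 (0.33 log units; beyond the scatter). For compound 4 the estimated value is 40000 nM, with an expected range of 10000 nM to 100000 nM.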

Compound 4, half-maximal cytotoxic concentration: 37000 nM
Compound 4: the middle estimate sits 1.1-fold (0.03 log units) above what was measured, within the range that was stated.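

In this assay, the saturated chain carbon bound to an oxygen on a saturated carbon takes 4-(3-hydroxyprop-1-yn-1-yl)phenyl in place of methyl with a 2.3-fold lower number from compound 3 to compound 4 (0.36 log units; beyond the scatter) as the outcome, so the value stays a measured number. That is a modest step for 10 heavy atoms entering against 1 leaving. No measured property in this set accounts for the step.

Open, on these data alone, is whether the phenyl ring or the hydroxypropynyl end carries the step. An unsubstituted phenyl, or an amine or carboxylic acid at the end of the alkyne chain, would separate the two.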